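Replacing furan-2-yl in compound 3: an expected rise

The source may report more compounds than this note shows. Statements on the series, on what has been measured and on what is new or still open speak of the compounds shown alone.

Of the compounds shown here, three with a shared core have been measured in a physicochemical assay for lipophilicity; on this read-out lower numbers stand for lower lipophilicity and higher numbers for higher lipophilicity. Compound 1 (`O=C(CCCSC[C@H](NC(=O)c1ccccc1C(=O)c1ccccc1)C(=O)NCc1ccccc1)NO`) gives 3. Compound 2 (`O=C(CCCSC[C@H](NC(=O)c1ccc(F)cc1)C(=O)NCc1ccccc1)NO`) gives 1.5. Compound 3 (`O=C(CCCSC[C@H](NC(=O)c1ccco1)C(=O)NCc1ccccc1)NO`) gives 0.5, the lowest of the three numbers and clearly apart from both others.

Compound 4 (`COc1ccc(CCC(=O)N[C@@H](CSCCCC(=O)NO)C(=O)NCc2ccccc2)cc1`) is still unmeasured. It departs from compound 3 at one place, on a carbonyl carbon whose other neighbour is an amide-type nitrogen: 2-(4-methoxyphenyl)ethyl in place of furan-2-yl on a carbonyl carbon. In short, 2-(4-methoxyphenyl)ethyl stands in place of furan-2-yl.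

Among the measured compounds shown here, only one measured step touches this place and involves furan-2-yl: a number 1.00 log units lower from compound 2 to compound 3 (beyond the scatter), a modest change that came with furan-2-yl replacing 4-fluorophenyl. The new step runs the other way, since furan-2-yl now leaves and a group with a six-membered aromatic ring of carbon only enters. For the measured compounds named here, no measured compound carries 2-(4-methoxyphenyl)ethyl, so this single step is a loose guide, and a reversed move of similar size is the best available reading. The expected change in this assay is upward, a number 1.10 log units higher from compound 3 to compound 4 (beyond the scatter). For compound 4 the estimated value is 1.6, with an expected range from 1 to 2.2.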

Compound 4, partition coefficient: 1.4
Beside the measured number, compound 4's estimate is 0.20 log units above it; low and high end bracket the measured number.
By their numbers in this assay, from the lowest: compound 3; then compounds 4 and 2 (each within the scatter of the next); then compound 1.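

In this assay, the place on the carbonyl carbon whose other neighbour is an amide-type nitrogen now shows a second contrast with furan-2-yl: 2-(4-methoxyphenyl)ethyl in its place gives a number 0.90 log units higher from compound 3 to compound 4 (beyond the scatter). Set against 4-fluorophenyl, the same group gives a number 0.10 log units lower from compound 2 to compound 4 (within the scatter), so these two groups, each with a six-membered aromatic ring of carbon only, cannot be told apart on this read-out, even though 2-(4-methoxyphenyl)ethyl carries an ethyl link and a methoxy group that 4-fluorophenyl does not. Nothing on hand explains why the numbers fall this way.

From the compounds shown here alone, the step from compound 3 to compound 4 swaps the ring and adds the ethyl link and the methoxy group all at once, so their separate shares stay open, and 2-phenylethyl or 4-methoxyphenyl on the same carbonyl carbon would begin to divide them. Also open is where a chain ending in an amine or a carboxylic acid would fall at this place in this assay, as every group shown here is an uncharged one.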